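Amine-to-methoxy swap on the aryl flanking the ring nitrogen

The source may report more compounds than this note shows. Statements on the series, on what has been measured and on what is new or still open speak of the compounds shown alone.

Two members of the series have been tested so far in a functional assay on DU-145 cells (Homo sapiens) for cytotoxicity, read by CCK-8 assay and cell counting, with a stated time of 72 h; a lower number here means a stronger inhibitor, a higher number a weaker inhibitor. Compound 1 `COc1ccc(-c2cc3ccccc3c(-c3cccc(OC)c3)n2)cc1` carries methoxyphenyl groups on both sides of the shared core and gives only a limit, > 50000 nM, so no number is available for it. Among the measured compounds shown here, compound 2 `COc1ccc(-c2cc3cc(C)ccc3c(-c3cccc(N)c3)n2)cc1OC` adds a methyl to the core, a 3,4-dimethoxyphenyl group and a 3-aminophenyl group; in this assay compound 2 gives 4190 nM, the only actual number in the set, the other entry being (the limit of > 50000 nM in this assay, at which 1 of the 2 values shown sits).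

Compound 3 `COc1ccc(-c2nc(-c3ccc(OC)c(OC)c3)cc3cc(C)ccc23)cc1` is the next candidate. Relative to compound 2 the change is 4-methoxyphenyl in place of 3-aminophenyl on an aromatic carbon. For the measured compounds named here, the aniline nitrogen, the single hydrogen-bond donor of compound 2, is thereby removed, and compound 3 ends up carrying only methoxy-substituted aryl groups, as compound 1 does, though the two differ in more than one place and compound 1 shows only a limit.

Going by the values given here, no measured step covers this change. Among the compounds with values here, compound 1, the one compound without an amine, gives only a limit, > 50000 nM. Compound 2 with its amine gives 4190 nM. On that basis the expectation for compound 3 is a loss of potency well beyond the scatter, a 4.8-fold higher number from compound 2 to compound 3 (0.68 log units; beyond the scatter). Compound 3 is estimated at 20000 nM, in the range 6000 nM to 60000 nM.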

Compound 3, half-maximal inhibitory concentration: > 50000 nM
Compound 3: no number, only a limit; the forecaster's own chance of this, stated with the estimate: 35%; middle value at least 2.5-fold (0.39 log units) away from the limit.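

In this assay the swap of 3-aminophenyl for 4-methoxyphenyl next to the ring nitrogen gives an at least 11-fold higher number from compound 2 to compound 3 (1.07 log units; beyond the scatter) and is the only single-place comparison shown, so this position is now seen to carry a large share of the activity that compound 2 has. Compound 3 gives > 50000 nM and that value is a limit, not a number. The size of the step is therefore a lower bound only, and how much activity remains in compound 3 cannot be read: the limit of > 50000 nM in this assay, at which 2 of the 3 values shown sit.

The compounds shown do not separate the loss of the amine from the shift of the substituent on the aryl ring, since both change in this one step; 4-aminophenyl and 3-methoxyphenyl at this position would pull the two apart. Among the compounds shown here, also open is whether the amine itself is needed or whether a hydroxyl or a methylamino group on the same aryl ring would hold the value of compound 2, which remains the only actual number.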